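Methoxy to Fluoro: What to Expect for Compound 4

The source may report more compounds than this note shows. Statements on the series, on what has been measured and on what is new or still open speak of the compounds shown alone.

Of the compounds shown here, three sharing one core have been tested in a functional assay on DLD-1 cells (Homo sapiens) for antiproliferative activity, read by MTT assay, with a stated time of 72 h; a lower number here means a stronger inhibitor, a higher number a weaker inhibitor. Compound 1 `COc1ccc(O)c(/C=C/C(=O)c2ccc(Cl)cc2)c1` gives 14700 nM, and compound 2 `O=C(/C=C/c1cc(F)ccc1O)c1ccc(Cl)cc1` gives 13200 nM; the step of a 1.1-fold lower number from compound 1 to compound 2 (0.05 log units; within the scatter) changes little. Compound 3 `COc1ccc(OC(=O)c2ccccc2OC(C)=O)c(/C=C/C(=O)c2ccc(Cl)cc2)c1` gives 2700 nM, the lowest of the three numbers, and the gap to both compound 1 and compound 2 lies beyond the scatter. Compound 4 `CC(=O)Oc1ccccc1C(=O)Oc1ccc(F)cc1/C=C/C(=O)c1ccc(Cl)cc1` has not yet been measured. It differs from compound 3 by fluoro in place of methoxy on an aromatic carbon. Going by the values given here, the only measured step with this same exchange is a 1.1-fold lower number from compound 1 to compound 2 (0.05 log units; within the scatter), which stayed within the scatter. A similarly small step is therefore expected for a 1.1-fold lower number from compound 3 to compound 4 (0.03 log units; within the scatter), with no clear direction. Compound 4 is thus estimated at 2500 nM, within a range from 1200 nM to 5500 nM.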

Compound 4, half-maximal inhibitory concentration: 3500 nM
Beside the measured number, compound 4's estimate is 1.4-fold (0.15 log units) below it, within the range that was stated.
By their numbers in this assay, from the lowest: compounds 3 and 4 (each within the scatter of the next); then compounds 2 and 1 (each within the scatter of the next).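

The exchange of methoxy for fluoro can now be read on a second core, that of compound 3, and there too it barely shifts the number in this assay (a 1.3-fold higher number from compound 3 to compound 4 (0.11 log units; within the scatter)). At this position, either group gives a similar reading on both cores, and the size of the step does not measurably depend on the core: the same change on two cores in this assay, a 1.1-fold lower number (0.05 log units; within the scatter) from compound 1 to compound 2 and a 1.3-fold higher number (0.11 log units; within the scatter) from compound 3 to compound 4, 1.4-fold (0.16 log units) apart, within the scatter of two such steps.

The compounds shown cover only methoxy and fluoro at this position, so how an amine or a carboxylic acid there would read stays open. Going by these compounds, whether the same holds in other cell types is also open.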